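The source may hold more compounds than are shown below. What is called first, only, known or untested is meant among the compounds shown, and "the series" means these compounds.

Values in a toxicity assay (J774.1 cells) for cytotoxicity, with Mus musculus as the target, read by resazurin assay, with a stated time of 24 h; on this read-out higher numbers stand for weaker inhibition and lower numbers for stronger inhibition:
- compound 1 `O=C(OCCCc1cccnc1)C1CCCCN1C(=O)COc1ccc(Cl)cc1` gives 50900 nM
- compound 2 `O=C(OCCCc1cccnc1)C1CCCCN1S(=O)(=O)Cc1cccc([N+](=O)[O-])c1` gives 46700 nM
- compound 3 `Nc1cccc(CS(=O)(=O)N2CCCCC2C(=O)OCCCc2cccnc2)c1` gives 62300 nM

Compound 2 lies within the scatter of both compound 1 and compound 3, so it holds no distinct place in the series. Compound 4 `O=C(OCCCc1cccnc1)[C@@H]1CCCCN1S(=O)(=O)Cc1cccc([N+](=O)[O-])c1` is still unmeasured. Its change from compound 2 is the two compounds have the same atoms and bonds; at least one stereo element is drawn with a configuration in one of them and without one in the other: 1 of 1 stereo elements differ; a stereocentre at a saturated ring carbon is drawn without a configuration in compound 2 and S in compound 4 and amounts to a stereocentre at a saturated ring carbon drawn without a configuration in compound 2 and S in compound 4. Within the data shown here, the one measured step of a 1.3-fold higher number from compound 2 to compound 3 (0.13 log units; within the scatter) is an amino-for-nitro swap within the scatter and does not touch this stereocentre, so no measured step tests the change directly. In this assay the expected step is a 1.0-fold higher number from compound 2 to compound 4 (0.00 log units; within the scatter) and no shift beyond the scatter is expected. Compound 4 is estimated at 47000 nM with an expected range of 25000 nM to 90000 nM for its value.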

Compound 4, half-maximal inhibitory concentration: 48200 nM
For compound 4 the middle estimate is 1.0-fold (0.01 log units) below the measured one; low and high end bracket the measured number.
By their numbers in this assay, from the lowest: compounds 2, 4, 1 and 3 (each within the scatter of the next).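

In this assay the stereocentre at the saturated ring carbon, drawn S, gives a 1.0-fold higher number from compound 2 to compound 4 (0.01 log units; within the scatter). Among these compounds, the earlier step left this stereocentre untouched; this is the first reading at this position, and it shows no shift beyond the scatter. The reading compares a defined drawing with an undefined one, not two opposite configurations: the fact that one of compounds 2 and 4 is drawn with a defined configuration and the other without, at the place where they differ

Going by these compounds, the R configuration at this ring carbon remains open. So does whether a carboxylic acid in place of the ester would shift the number in this assay.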